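Swapping a methoxy for a chloro on the benzyl arm

The source may report more compounds than this note shows. Statements on the series, on what has been measured and on what is new or still open speak of the compounds shown alone.

Three related hydrazones share one core, and all of them are weak in a functional assay on MIA PaCa-2 cells (Homo sapiens) for cytotoxicity; a higher number here means a weaker inhibitor, a lower number a stronger inhibitor. Compound 1 `O=C(N/N=C\c1cn(Cc2ccc(Cl)cc2)c2cc(F)ccc12)c1c[nH]c2ccccc12` gives 18000 nM. Compound 2 `Cn1cc(C(=O)N/N=C\c2cn(Cc3ccc(Cl)cc3)c3cc(F)ccc23)c2ccccc21` gives 50400 nM, and the only single-point step among these compounds, a 2.8-fold higher number from compound 1 to compound 2 (0.45 log units; beyond the scatter), is a methyl in place of hydrogen on an aromatic nitrogen. Compound 3 `COc1ccc(Cn2cc(/C=N\NC(=O)c3c[nH]c4ccc(Br)cc34)c3ccc(F)cc32)cc1` gives 45500 nM, the second highest of the three numbers, within the scatter of compound 2 and beyond it relative to compound 1.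

Compound 4 `O=C(N/N=C\c1cn(Cc2ccc(Cl)cc2)c2cc(F)ccc12)c1c[nH]c2ccc(Br)cc12` differs from compound 3 in one place: chloro in place of methoxy on an aromatic carbon. Among the measured compounds shown here, no measured step covers this change; the one measured step concerns a different position. Compound 1, which also carries the chlorobenzyl arm but lacks the bromo, sits lower than compound 3, though two changes separate those two. Compound 4 is therefore expected to land between them, with the step of a 1.8-fold lower number from compound 3 to compound 4 (0.26 log units; within the scatter) estimated as a modest drop. The estimate for compound 4 in this assay is 25000 nM, with a likely range from 10000 nM to 60000 nM.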

Compound 4, half-maximal inhibitory concentration: 10600 nM
The estimate for compound 4 lay 2.4-fold (0.37 log units) above the measured number, and the stated range covers the measured number.
By their numbers in this assay, from the lowest: compounds 4 and 1 (each within the scatter of the next); then compounds 3 and 2 (each within the scatter of the next).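

Among the compounds shown here, on the benzyl arm, chloro in place of methoxy para to a large group gives a 4.3-fold lower number from compound 3 to compound 4 (0.63 log units; beyond the scatter) in this assay, which is the first measured step at this position and lies beyond the scatter. The other two steps separate the indole changes: 5-bromo-1H-indol-3-yl in place of 1-methyl-1H-indol-3-yl gives a 4.8-fold lower number from compound 2 to compound 4 (0.68 log units; beyond the scatter), also beyond the scatter, whereas bromo in place of hydrogen alone gives a 1.7-fold lower number from compound 1 to compound 4 (0.23 log units; within the scatter), within the scatter, so that single addition shows no clear effect on the number. Nothing available here explains why the chloro and methoxy compounds differ.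

Still open, on these data alone, is how a trifluoromethyl, a nitrile or an amine at this same place would compare with chloro and methoxy. Also open, as far as these compounds go, is whether the methoxy-to-chloro step keeps its size on the indole without bromo, as found in compound 1.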